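The compounds below may be only part of what the source reports. "The series", "measured", "known", "first", "only" and "open" are said of these compounds alone.

Measured so far:
- compound 1 `OC[C@H](NC1CCN(CCCc2c[nH]c3ccc(-n4ccnc4)cc23)CC1)c1ccccc1`: 74% in a functional assay on CHO cells for activation of 5-hydroxytryptamine receptor 1D (Homo sapiens), read by GTPgammaS binding; a higher number here means a larger maximal response, a lower number a smaller maximal response
- compound 2 `c1ccc2c(c1)CCC2NC1CCN(CCCc2c[nH]c3ccc(-n4cnnc4)cc23)CC1`: 68% in this assay

Both numbers come from the same assay. Going by the values given here, the gap between compound 2 and compound 1 falls within the usual scatter, so no order between the two can be read; compound 2 simply sits in the same band as compound 1, and there is no step between measured compounds to lean on.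

Compound 3 `CC(CO)(NC1CCN(CCCc2c[nH]c3ccc(-n4cnnc4)cc23)CC1)c1ccccc1` has not yet been measured. It follows from compound 2 by one change on the shared core: 1-(hydroxymethyl)-1-phenylethyl in place of 2,3-dihydro-1H-inden-1-yl on an amine nitrogen

Compound 3 thus carries a hydroxymethyl-bearing side group of the same kind as compound 1, whose value in this assay is 74%, while keeping the rest of compound 2. With only two measured points, both within scatter of each other, the step is expected to be small: a number 3 percentage points higher from compound 2 to compound 3 (within the scatter) is estimated to stay within the scatter, with no clear direction. For compound 3 the expected value in this assay is 71%, in the range 55% to 87%.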

Compound 3, largest response reached (reported as efficacy), in percent of the reference or control that the assay uses: 59%
Compound 3: middle estimate off by 12 percentage points, on the high side; the measured number falls inside the stated range.
By their numbers in this assay, from the lowest: compounds 3, 2 and 1 (each within the scatter of the next, the first and the last beyond it).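

In this assay, going by these compounds alone, 1-(hydroxymethyl)-1-phenylethyl in place of 2,3-dihydro-1H-inden-1-yl on an amine nitrogen gives a number 9 percentage points lower from compound 2 to compound 3 (within the scatter) and is the only single-place step. At this position, the five-membered non-aromatic ring can thus give way to an open group carrying a hydrogen-bond donor and acceptor, with no difference that can be told from scatter. Nothing at hand bears on why the step has this size.

Open, going by these compounds, is whether an amine or a carboxylic acid in place of the hydroxyl of the hydroxymethyl group would keep the maximal response in the same band. Also open, on these data alone, is whether the same exchange reads alike on the core of compound 1, as this single step cannot show that.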